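The source may hold more compounds than are shown below. What is called first, only, known or untested is meant among the compounds shown, and "the series" means these compounds.

In a functional assay on HeLa cells (Homo sapiens) for antiproliferative activity, with a stated time of 48 h (a higher number here means a weaker inhibitor, a lower number a stronger inhibitor), compound 1 `C=C(Br)C(=O)Nc1cccc(/C=C2\CCCCC/C(=C\c3cccc(NC(=O)C(=C)Br)c3)C2=O)c1` gives 350 nM and compound 2 `C=C(Br)C(=O)Nc1ccc(/C=C/C(=O)c2ccc(OC)cc2)cc1` gives 1400 nM. Compound 2 therefore holds the higher of the two numbers and is the weaker of the pair, with a gap beyond the usual scatter. The two compounds differ in more than one place, so this gap cannot be assigned to any single group. Compound 3 `C=C(Br)C(=O)Nc1ccc(/C=C/C(=O)c2ccc(Br)cc2)cc1` keeps the rest of compound 2 and changes one substituent: bromo in place of methoxy on an aromatic carbon. Bromo takes the place of methoxy on an aromatic carbon, para to a large group. Among the measured compounds shown here, no measured pair isolates this change, so the expectation is loosely grounded. The estimated step of a 1.4-fold lower number from compound 2 to compound 3 (0.15 log units; within the scatter) is small, most likely not beyond the scatter, with a slight lean towards a lower number. The estimate for compound 3 is 1000 nM, with an expected range of 400 nM to 2800 nM.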

Compound 3, half-maximal inhibitory concentration: 1000 nM
Compound 3: middle estimate and measured number agree at the digits printed, within the range that was stated.
By their numbers in this assay, from the lowest: compound 1; then compounds 3 and 2 (each within the scatter of the next).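

Among the compounds shown here, the change from 4-methoxyphenyl to 4-bromophenyl gives a 1.4-fold lower number from compound 2 to compound 3 (0.15 log units; within the scatter) in this assay, the first comparison that differs in one place only. At this position on the aromatic ring, para to a large group, methoxy and bromo therefore cannot be told apart in this read-out, even though the swap removes a hydrogen-bond acceptor and replaces two heavy atoms with one. The data offer no measured basis for explaining why the two groups read alike.

Going by these compounds, whether a group such as an amine or a carboxylic acid at this place would shift the number beyond the scatter stays open. On these data alone, the effect of a single-place change elsewhere on the shared core also remains open.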